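Working notes on the step from compound 2 to compound 3

A few compounds are considered here, and "the series" means these few. Any claim that something is new, unique, unknown or untested is made for them only; others in the source may bear on it.

Measured so far:
compound 1 `O=C(Nc1c(C(O)(C(F)(F)F)C(F)(F)F)ccc2ccccc12)C1CCC1`: 45 nM
compound 2 `O=C(Nc1ccc(Cl)cc1)Nc1c(C(O)(C(F)(F)F)C(F)(F)F)ccc2ccccc12`: 276 nM

Both numbers come from an assay on LtK cells with ATP-sensitive inward rectifier potassium channel 11 (Homo sapiens) as the target; a higher number here means that more compound is needed for the effect, a lower number that less compound is needed. Going by the values given here, compound 2 holds the higher of the two numbers in this assay; its nearest neighbour is compound 1, and the single measured step, a 6.1-fold higher number from compound 1 to compound 2 (0.79 log units; beyond the scatter), carries the change of (4-chlorophenyl)amino in place of cyclobutyl on a carbonyl carbon.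

Compound 3 `O=C(Nc1c(C(O)(C(F)(F)F)C(F)(F)F)ccc2ccccc12)c1cccc([N+](=O)[O-])c1` is not yet measured. Against compound 2 it differs as follows: 3-nitrophenyl in place of (4-chlorophenyl)amino on a carbonyl carbon

Among the compounds with values here, only the step from compound 1 to compound 2 bears on this, and only loosely: it shows that the (4-chlorophenyl)amino group on the carbonyl carbon went with a higher number than cyclobutyl, so taking that group away again is the kind of change that could bring the number back down. Within the data shown here, no measured pair shows a 3-nitrophenyl group on a carbonyl carbon, so the size of the effect is uncertain. The expected step is a 2.5-fold lower number from compound 2 to compound 3 (0.40 log units; beyond the scatter), modest and with wide bounds. The estimate for compound 3 in this assay is 110 nM, within 35 nM to 350 nM.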

Compound 3, half-maximal effective concentration: 117 nM
Compound 3: middle estimate off by 1.1-fold (0.03 log units), on the low side; the range from low to high includes it.
By their numbers in this assay, from the lowest: compound 1; then compound 3; then compound 2.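

At the carbonyl carbon, in this assay, the change to 3-nitrophenyl gives a 2.4-fold lower number from compound 2 to compound 3 (0.37 log units; beyond the scatter), so a six-membered aromatic ring at this place does not by itself go with a number as high as that of compound 2. The same group still gives a 2.6-fold higher number from compound 1 to compound 3 (0.41 log units; beyond the scatter), which places compound 3 between the other two compounds, with all three differences beyond the scatter, and shows that removing (4-chlorophenyl)amino does not by itself restore the number seen with cyclobutyl. No measurement available here explains either step, and the change from compound 2 to compound 3 alters the amino nitrogen, the chlorine and the nitro group at once, so the step cannot be assigned to any one of them.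

The compounds shown leave open whether the lower number of compound 3 relative to compound 2 goes with the loss of the amino nitrogen or with the exchange of ring substituents. A plain phenyl group and a (3-nitrophenyl)amino group on the same carbonyl carbon would separate these two changes, while a cyclopentyl group would test how far the low number of compound 1 extends among saturated rings.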